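Methyl on the Pyridine Ring: Small Change, Small Compounds

The source may report more compounds than this note shows. Statements on the series, on what has been measured and on what is new or still open speak of the compounds shown alone.

Measured so far:
Compound 1, `N/C(=N\NC(=S)N1CCCCCC1)c1ccccn1`: 21.3%
Compound 2, `N/C(=N\NC(=S)N1CCOCC1)c1ccccn1`: 12.7%

Both compounds share a core built around a thiosemicarbazone and a six-membered aromatic ring with one nitrogen; they differ only in the saturated ring attached at the thiourea end. In a functional assay on HeLa cells (Homo sapiens) for cytotoxicity, read by MTT assay, with a stated time of 72 h, tested at 1 uM (on this read-out lower numbers stand for less inhibition of growth and higher numbers for more inhibition of growth at the one concentration tested), compound 1 gives 21.3%, and in this assay compound 2 gives 12.7%. Compound 2 has the lower of the two numbers, but the gap to compound 1 is within the usual scatter of this kind of measurement, so the two compounds cannot be told apart on these data; both show only modest inhibition of growth at the single concentration tested.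

Compound 3, `Cc1ccnc(/C(N)=N/NC(=S)N2CCOCC2)c1`, keeps the whole of compound 2 and adds one change: methyl in place of hydrogen on an aromatic carbon. The methyl sits on an aromatic carbon of the six-membered aromatic ring with one nitrogen, opposite the ring nitrogen.

Within the data shown here, no pair of measured compounds carries this change, so there is nothing to scale an expectation from. A single methyl group added to a compound that already sits low in this assay is expected to move the number little, if at all, in either direction; the step of a number 1.3 percentage points higher from compound 2 to compound 3 (within the scatter) is expected to stay within the scatter. For compound 3 the estimate is 14%, with a range from 3% to 28%.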

Compound 3, percent growth inhibition at one concentration: 39.1%
The estimate for compound 3 lay 25.1 percentage points below the measured number, outside the stated range (above it).
By their numbers in this assay, from the lowest: compounds 2 and 1 (each within the scatter of the next); then compound 3.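

Compound 3 shows that this place on the aromatic ring, opposite the ring nitrogen, matters in this assay: methyl in place of hydrogen gives a number 26.4 percentage points higher from compound 2 to compound 3 (beyond the scatter), although the change adds only one heavy atom. Among these compounds, the two earlier compounds differ only in the saturated ring at the thiourea end, so they could say nothing about the aromatic ring; this pair is the first evidence that a change there can move the number beyond the usual scatter. Nothing available here explains how the methyl produces this step.

The compounds shown leave open whether the effect belongs to methyl in particular or would also appear with a longer chain such as ethyl, with a halogen such as chlorine, or with an amine at the same place, and whether methyl at other places on the aromatic ring would do the same. They also leave open whether the step carries over to the shared core with the saturated ring of compound 1, and, as each number comes from a single concentration, how the compounds would compare across a range of concentrations.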